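The source may hold more compounds than are shown below. What is called first, only, known or untested is meant among the compounds shown, and "the series" means these compounds.

In a functional assay on PANC-1 cells (Homo sapiens) for inhibition, read by MTT assay, with a stated time of 24 h, tested at 10 uM (on this read-out lower numbers stand for less inhibition and higher numbers for more inhibition at the one concentration tested (going by the name of the read-out)), the three measured compounds read as follows:

Compound 1, `CC(C)=CCC1Cc2c(OCc3ccccc3)cc(=O)n(CCCO)c2CC1(C)C`: 11.1%
Compound 2, `CC(C)=CCC1Cc2c(OCCCNC(=O)c3cccs3)cc(=O)n(CCCO)c2CC1(C)C`: 5.6%
Compound 3, `COc1ccc(NC(=O)Oc2cc(=O)n(CCCO)c3c2CC(CC=C(C)C)C(C)(C)C3)cc1`: 0%

Compound 3 holds the lowest of these three numbers. Its gap to compound 2, a number 5.6 percentage points lower from compound 2 to compound 3 (within the scatter), is within the scatter, whereas the step of a number 11.1 percentage points lower from compound 1 to compound 3 (beyond the scatter) is beyond it, though modest. Compound 4, `CC(C)=CCC1Cc2c(OC(=O)Nc3ccccc3F)cc(=O)n(CCCO)c2CC1(C)C`, differs from compound 3 by 2-fluorophenyl in place of 4-methoxyphenyl on an amide-type nitrogen. For the measured compounds named here, every measured step so far changes the group on the oxygen on the aromatic ring; none changes the group on the amide-type nitrogen, so no measured step bears directly on this change. With nothing to suggest otherwise, a step of a number 4 percentage points higher from compound 3 to compound 4 (within the scatter) is expected, that is, nothing beyond the scatter. Compound 4 is therefore estimated at 4%, with a range from 0% to 15%.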

Compound 4, a percentage reported as inhibition, at one concentration (the size of the read-out at that concentration, not a potency): 0%
Estimate against measurement, compound 4: 4 percentage points above; measured number inside the range.
By their numbers in this assay, from the lowest: compounds 3, 4, 2 and 1 (each within the scatter of the next, the first and the last beyond it).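

In this assay, for the compounds shown here, the first measured change on the amide-type nitrogen, 2-fluorophenyl in place of 4-methoxyphenyl, gives no change at the digits printed from compound 3 to compound 4 (within the scatter) and so does not separate these two groups. Against the other compounds, a number 5.6 percentage points lower from compound 2 to compound 4 (within the scatter) stays small, while a number 11.1 percentage points lower from compound 1 to compound 4 (beyond the scatter) matches the modest step already seen for compound 3. Nothing available explains these readings. Still open, on these data alone, is whether an amine or a carboxylic acid on the phenyl ring, or a straight alkyl chain in its place on the amide-type nitrogen, would change the number.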